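Methyl in place of chloro: cytotoxicity on the benzyl arm

A few compounds are considered here, and "the series" means these few. Any claim that something is new, unique, unknown or untested is made for them only; others in the source may bear on it.

Compound 1 `CC(C)CCN1C(=O)C(C2=NS(=O)(=O)c3cc(NS(C)(=O)=O)ccc3N2)=C(O)C2CCCC21` and compound 2 `CS(=O)(=O)Nc1ccc2c(c1)S(=O)(=O)N=C(C1=C(O)[C@H]3CCC[C@H]3N(Cc3ccc(F)c(Cl)c3)C1=O)N2` share the same core and differ in the substituent attached to it. In an ADME assay on Huh-7 cells (Homo sapiens) for cytotoxicity, with a stated time of 72 h (a higher number here means that more compound is tolerated, a lower number that less compound is tolerated), compound 1 reaches only a limit of the assay, > 1000 nM. Compound 2 likewise reaches only a limit in this assay, > 1000 nM. For the measured compounds named here, both values sit at the limit of > 1000 nM in this assay, at which 2 of the 2 values shown sit, so compound 2 stands level with the one other measured compound, and no order between the two can be read from these numbers.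

Compound 3 `Cc1cc(CN2C(=O)C(C3=NS(=O)(=O)c4cc(NS(C)(=O)=O)ccc4N3)=C(O)[C@H]3CCC[C@H]32)ccc1F` is the next analogue of compound 2, and the change is methyl in place of chloro on an aromatic carbon, in words a methyl in place of chloro on an aromatic carbon. Going by the values given here, no step between two measured compounds is available here. For a swap of this kind, with the shared core untouched, the expected step in this assay is none beyond the scatter, and the expected value is likely to come back as a limit of the assay again. The step from compound 2 to compound 3 is therefore estimated as a step that the limit leaves unreadable from compound 2 to compound 3. On that basis compound 3 is expected to give 2000 nM in this assay, within a range of 800 nM to 10000 nM.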

Compound 3, half-maximal cytotoxic concentration: > 1000 nM
Compound 3 was reported as a limit; the forecaster's own chance of this, stated with the estimate: 85%; the middle value lies beyond the limit too.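

In this assay compound 3 gives > 1000 nM, which is a limit of the assay. Compound 2 also stands at a limit, so no step can be read between compound 2 and compound 3: the limit of > 1000 nM in this assay, at which 3 of the 3 values shown sit.

The compounds shown leave open the actual half-maximal cytotoxic concentration of each compound, and whether the 3-chloro-4-fluorobenzyl and 4-fluoro-3-methylbenzyl arms differ at all in this assay.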